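This account rests on a few compounds, and the source may have more. Where it says the series, first, only, none or still open, it means among the compounds named here.

Of the compounds shown here, three built on one shared core have been tested in a functional assay on the whole organism (spleen, spleen) with Rattus norvegicus as the target; on this read-out higher numbers stand for an effect only at larger amounts of compound and lower numbers for an effect already at smaller amounts. Compound 1 `CCCCCCCOc1ccc(CCC(N)(CO)CO)cc1` gives 0.014 mg/kg. Compound 2 `C=CCC(N)(CO)CCc1ccc(OCCCCCCC)cc1` gives 3.1 mg/kg, and compound 3 `CCCCCCCOc1ccc(CCC(N)(CO)CCC)cc1` gives 7.3 mg/kg. Compound 3 therefore stands at the highest number of the three: the step is a 2.4-fold higher number from compound 2 to compound 3 (0.37 log units; beyond the scatter) and, against the lowest compound, a 520-fold higher number from compound 1 to compound 3 (2.72 log units; beyond the scatter).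

Compound 4 `CCCCCCCOc1ccc(CCC(N)(CO)CCO)cc1` has not yet been measured in this assay. It differs from compound 3 by hydroxy in place of methyl on a saturated chain carbon, three bonds along the chain from an amine nitrogen. Going by the values given here, two measured steps bear on this change. Going from a hydroxy to an ethyl at the chain carbon gave a 520-fold higher number from compound 1 to compound 3 (2.72 log units; beyond the scatter), and going from a hydroxy to a vinyl gave a 220-fold higher number from compound 1 to compound 2 (2.35 log units; beyond the scatter), so in this small set the loss of a hydroxy on that chain went with a large rise in the number. From the compounds shown here alone, compound 4 brings a hydroxy back, though one bond further from the nitrogen than in compound 1, and the effect of that longer placement is unknown here.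

A large step downward is therefore expected, though not necessarily all the way back to compound 1: the estimate for compound 4 is 0.3 mg/kg, within 0.04 mg/kg to 2.5 mg/kg, which means an expected step of a 24-fold lower number from compound 3 to compound 4 (1.39 log units; beyond the scatter).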

Compound 4, dose for 50% inhibition: 0.055 mg/kg
Beside the measured number, compound 4's estimate is 5.5-fold (0.74 log units) above it; the range from low to high includes it.
By their numbers in this assay, from the lowest: compound 1; then compound 4; then compound 2; then compound 3.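

In this assay, swapping the end methyl of the propyl chain for hydroxy, which makes a 2-hydroxyethyl group, moves the number down sharply (a 130-fold lower number from compound 3 to compound 4 (2.12 log units; beyond the scatter)), and the same group in place of the vinyl-bearing chain also gives a large drop (a 56-fold lower number from compound 2 to compound 4 (1.75 log units; beyond the scatter)). The earlier compounds shown here showed only that losing the hydroxy went with a large rise in the number, whereas this result shows that a hydroxy three bonds along the chain from an amine nitrogen recovers most of that loss, leaving only a modest gap to the hydroxymethyl compound (a 3.9-fold higher number from compound 1 to compound 4 (0.59 log units; beyond the scatter)). No measurement here explains why this single-atom change has so large an effect.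

The compounds shown leave open how far along the chain the hydroxy can sit, since a longer chain such as 3-hydroxypropyl does not appear among them. They also leave open whether another group at the chain end, such as an amine, a methoxy or a carboxylic acid, could take the place of the hydroxy.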